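Replacing the Ring-Nitrogen Carbamate with a Benzyl Group

The compounds below may be only part of what the source reports. "The series", "measured", "known", "first", "only" and "open" are said of these compounds alone.

Measured so far in an assay on isolated protein for inhibition of Fatty-acid amide hydrolase 1 (Homo sapiens); a higher number here means a weaker inhibitor, a lower number a stronger inhibitor:
compound 1 `O=C(CCCC1CCN(C(=O)c2ccccc2)CC1)c1ncco1` gives 77 nM;
compound 2 `CC(C)(C)CC(=O)N1CCC(CCCC(=O)c2ncco2)CC1` gives 90 nM;
compound 3 `CC(C)OC(=O)N1CCC(CCCC(=O)c2ncco2)CC1` gives 4 nM.

Compound 3 holds the lowest number of the three, and both of its steps from the others are beyond the scatter. The change from phenyl to neopentyl on a carbonyl carbon, a 1.2-fold higher number from compound 1 to compound 2 (0.07 log units; within the scatter), hardly moved the number, whereas isopropoxy on that carbonyl carbon brought a 19-fold lower number from compound 1 to compound 3 (1.28 log units; beyond the scatter) and a 23-fold lower number from compound 2 to compound 3 (1.35 log units; beyond the scatter), both large drops.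

Compound 4 `Cc1ccc(CN2CCC(CCCC(=O)c3ncco3)CC2)cc1` differs from compound 3 in one place: 4-methylbenzyl in place of isopropoxycarbonyl on an amine nitrogen in a ring. Here the whole isopropoxycarbonyl group leaves, carbonyl included, and a 4-methylbenzyl group with no hydrogen-bond acceptors enters on the amine nitrogen in the ring. For the measured compounds named here, none of the measured steps removes the carbonyl; they only exchange what sits on it, and the two exchanges that lack isopropoxy gave numbers far higher than compound 3. The best guide is therefore that losing the isopropoxycarbonyl group costs most of its advantage, and the new group may cost more.

Compound 4 is expected to give about 600 nM, within 60 nM to 6000 nM, which means an estimated step of a 150-fold higher number from compound 3 to compound 4 (2.18 log units; beyond the scatter) in this assay.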

Compound 4, half-maximal inhibitory concentration: 400 nM
Compound 4: middle estimate off by 1.5-fold (0.18 log units), on the high side; measured number inside the range.
By their numbers in this assay, from the lowest: compound 3; then compounds 1 and 2 (each within the scatter of the next); then compound 4.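

For the compounds shown here, compound 4 is the only compound here in which the carbonyl on the amine nitrogen in the ring is gone altogether, rather than only what sits on it being exchanged, and in this assay the change brings a 100-fold higher number from compound 3 to compound 4 (2.00 log units; beyond the scatter) as the largest step so far. The rise is not limited to the comparison with isopropoxycarbonyl: there is also a 4.4-fold higher number from compound 2 to compound 4 (0.65 log units; beyond the scatter) and a 5.2-fold higher number from compound 1 to compound 4 (0.72 log units; beyond the scatter) as well, both modest but beyond the scatter, so all three compounds with a carbonyl on that nitrogen give lower numbers than compound 4. The step from benzoyl is the closest comparison, as both groups hold a six-membered aromatic ring of carbon only, so that ring alone does not separate compound 1 from compound 4.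

The change from benzoyl to 4-methylbenzyl removes the carbonyl and adds a methyl group together, so a plain benzyl group, or a urea on the same nitrogen, would be needed to tell how much each part counts. The data shown offer no measurement that explains the size of these steps.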